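This account rests on a few compounds, and the source may have more. Where it says the series, first, only, none or still open, it means among the compounds named here.

Measured compounds:
Compound 1 `COc1ccc(OC)c(/C=N/NC(=O)Nc2ccc(Oc3ccnc(-c4nncn4CCN(C)C)c3)c(F)c2)c1`, which in a functional assay on A549 cells (Homo sapiens) for cytotoxicity, read by MTT assay, with a stated time of 72 h (a lower number here means a stronger inhibitor, a higher number a weaker inhibitor), gives 1950 nM.
Compound 2 `COc1ccc(/C=N/NC(=O)Nc2ccc(Oc3ccnc(-c4nncn4CCN(C)C)c3)c(F)c2)c(OC)c1`, which in this assay gives 2820 nM.
Compound 3 `CN(C)CCn1cnnc1-c1cc(Oc2ccc(NC(=O)N/N=C/c3ccc(F)cc3F)cc2F)ccn1`, which in this assay gives 1870 nM.

All three share the same core and differ only in the aromatic group attached to the carbon that carries a double bond to nitrogen. Compound 3 has the lowest of the three numbers, but the step of a 1.0-fold lower number from compound 1 to compound 3 (0.02 log units; within the scatter) and the step of a 1.5-fold lower number from compound 2 to compound 3 (0.18 log units; within the scatter) are both within the scatter, so none of the three stands apart from the others.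

Compound 4 `COc1cc(/C=N/NC(=O)Nc2ccc(Oc3ccnc(-c4nncn4CCN(C)C)c3)c(F)c2)cc(OC)c1OC` has not yet been measured. It differs from compound 3 in that (3,4,5-trimethoxyphenyl in place of 2,4-difluorophenyl on a carbon with a double bond to nitrogen).

The three known steps all swap the aromatic group at this same position: a 1.4-fold higher number from compound 1 to compound 2 (0.16 log units; within the scatter), a 1.0-fold lower number from compound 1 to compound 3 (0.02 log units; within the scatter) and a 1.5-fold lower number from compound 2 to compound 3 (0.18 log units; within the scatter). Each of them is within the scatter, whether the ring carries fluorines or methoxy groups, so for the move to a ring with three methoxy groups no step beyond the scatter in this assay is expected. Compound 4 is therefore estimated at 2000 nM, with a range from 800 nM to 5000 nM, which amounts to an expected step of a 1.1-fold higher number from compound 3 to compound 4 (0.03 log units; within the scatter).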

Compound 4, half-maximal inhibitory concentration: > 100000 nM
Compound 4: no number, only a limit (the forecaster's own chance of this, stated with the estimate: 5%); middle value at least 50-fold (1.69 log units) away from the limit.
By their numbers in this assay, from the lowest: compounds 3, 1 and 2 (each within the scatter of the next). At a limit, above all of these: compound 4.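

Going by these compounds alone, the aromatic group on the carbon with a double bond to nitrogen can clearly matter in this assay, which the earlier compounds did not reveal: the 3,4,5-trimethoxyphenyl group brings an at least 53-fold higher number from compound 3 to compound 4 (1.72 log units; beyond the scatter), an at least 35-fold higher number from compound 2 to compound 4 (1.54 log units; beyond the scatter) and an at least 51-fold higher number from compound 1 to compound 4 (1.70 log units; beyond the scatter). The result for compound 4 is a limit and not a number: the limit of > 100000 nM in this assay, at which 1 of the 4 values shown sits. Methoxy groups alone do not go with this loss, since compound 1 and compound 2 also carry them and lie within the scatter of compound 3.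

The compounds shown cannot separate the effect of having three methoxy groups from the effect of where they sit on the ring. They also leave open how a ring with a single methoxy group, an amine or a carboxylic acid would behave at this position.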